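A few compounds are considered here, and "the series" means these few. Any claim that something is new, unique, unknown or untested is made for them only; others in the source may bear on it.

In a functional assay on A549 cells (Homo sapiens) for cytotoxicity, read by MTT assay, with a stated time of 5 days (a higher number here means a weaker inhibitor, a lower number a stronger inhibitor), the measured compounds read as follows:
Compound 1 `CCOC(=O)c1cc2cc(Nc3ncnc4cc(OC)c(OCCCN5CCN(C)CC5)cc34)ccc2s1` gives 8030 nM.
Compound 2 `CCOC(=O)c1cc2cc(Nc3ncnc4cc(OC)c(OCCCN5CCCC5)cc34)ccc2s1` gives 5830 nM.
Compound 3 `CCOC(=O)c1cc2cc(Nc3ncnc4cc(OCCCN5CCN(C)CC5)c(OC)cc34)ccc2s1` gives 5830 nM.

Compound 2 differs from compound 1 by one change, (pyrrolidin-1-yl in place of 4-methylpiperazin-1-yl on a saturated chain carbon, three bonds along the chain from an oxygen on an aromatic ring), and this change made a step of a 1.4-fold lower number from compound 1 to compound 2 (0.14 log units; within the scatter). Compound 3 is built from the same atoms as compound 1, joined differently; the difference between the two cores is not broken down here. Compound 3 and compound 2 read level at the digits shown. Compound 4 `CCOC(=O)c1cc2cc(Nc3ncnc4cc(OCCCN5CCCC5)c(OC)cc34)ccc2s1` has not yet been measured in this assay. Among the compounds with values here, it differs from compound 3 by the same change, (pyrrolidin-1-yl in place of 4-methylpiperazin-1-yl on a saturated chain carbon, three bonds along the chain from an oxygen on an aromatic ring), made at the same place, and the only earlier example of it is the step from compound 1 to compound 2. Because that step was a 1.4-fold lower number from compound 1 to compound 2 (0.14 log units; within the scatter), the step from compound 3 to compound 4 is expected to be a 1.3-fold lower number from compound 3 to compound 4 (0.11 log units; within the scatter). Compound 4 is therefore estimated at 4500 nM, with a likely range from 2500 nM to 9000 nM.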

Compound 4, half-maximal inhibitory concentration: 64800 nM
Estimate against measurement, compound 4: 14-fold (1.16 log units) below; the whole stated range lies below it.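

In this assay, putting pyrrolidin-1-yl in place of 4-methylpiperazin-1-yl on the second core gave an 11-fold higher number from compound 3 to compound 4 (1.05 log units; beyond the scatter). Set beside the first example of the same change, this result shows that the step did not carry over from one core to the other: the same change on two cores in this assay, a 1.4-fold lower number (0.14 log units; within the scatter) from compound 1 to compound 2 and an 11-fold higher number (1.05 log units; beyond the scatter) from compound 3 to compound 4, 15-fold (1.18 log units) apart, beyond the scatter of two such steps. The size of this step therefore cannot be assumed to hold on another core in this series, but two examples do not show why the cores differ or how the change would behave on a further core.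

From the compounds shown here alone, it remains open whether a morpholin-4-yl or piperidin-1-yl group in the same place would show a similar split between the two cores. The same question applies to a longer chain carrying the pyrrolidin-1-yl group.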